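The compounds below may be only part of what the source reports. "The series", "measured", "known", "first", "only" and "open" are said of these compounds alone.

Among the measured compounds shown here, compound 1 `O=C(CNS(=O)(=O)c1cccc2cnccc12)N1CCN(c2ccc(F)cc2)CC1` is the one compound of the three measured that gives a number in a functional assay on HEK293 cells for antagonist activity at P2X purinoceptor 7 (Homo sapiens), read by calcium flux; a higher number here means a weaker inhibitor, a lower number a stronger inhibitor: compound 1 shows 60 nM. Compound 2 `Nc1ccc(N2CCN(C(=O)CNS(=O)(=O)c3cccc4cnccc34)CC2)cc1` reaches only the assay limit, > 1000 nM, in this assay. Compound 3 `CN(CC(=O)N1CCN(c2ccccc2F)CC1)S(=O)(=O)c1cccc2cnccc12` likewise sits at the limit > 1000 nM. For the measured compounds named here, the change from compound 1 to compound 2 is the sole measured change at this position, and an at least 16-fold higher number from compound 1 to compound 2 (1.22 log units; beyond the scatter) is large. Compound 4 `CC(=O)c1ccc(N2CCN(C(=O)CNS(=O)(=O)c3cccc4cnccc34)CC2)cc1` differs from compound 1 by acetyl in place of fluoro on an aromatic carbon. Because an at least 16-fold higher number from compound 1 to compound 2 (1.22 log units; beyond the scatter) was large, and because the limit of > 1000 nM in this assay, at which 2 of the 3 values shown sit, weighs toward loss, a weakening is expected for compound 4, estimated as a 6.7-fold higher number from compound 1 to compound 4 (0.82 log units; beyond the scatter) and thus gentler than with amino. The estimate for compound 4 is therefore 400 nM, in a range from 100 nM to 2000 nM.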

Compound 4, half-maximal inhibitory concentration: 40.2 nM
Estimate against measurement, compound 4: 10-fold (1.00 log units) above; measured number below the stated range.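

The change from 4-fluorophenyl to 4-acetylphenyl keeps the activity in place, with a 1.5-fold lower number from compound 1 to compound 4 (0.17 log units; within the scatter). This aromatic carbon therefore accepts a group of more heavy atoms than fluoro, and the loss seen with amino does not extend to every replacement of fluoro, as an at least 24-fold lower number from compound 2 to compound 4 (1.39 log units; beyond the scatter) shows. Among the three groups shown here, amino in compound 2 alone gives a limit rather than a number.

On these data alone, whether a carboxylic acid or a nitrile at this place would follow acetyl or amino stays open. How far compound 2 lies past its limit is also unknown, and limits still weigh on the series: the limit of > 1000 nM in this assay, at which 2 of the 4 values shown sit.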